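The compounds below may be only part of what the source reports. "The series", "measured", "known", "first", "only" and "open" are said of these compounds alone.

Compound 1 `COc1cc(N(Cc2ccc(F)cc2)C(=O)CSc2nc3ccccc3s2)cc(OC)c1OC` is the weakest of the three measured compounds in a functional assay on HCT-116 cells (Homo sapiens) for antiproliferative activity, read by MTT assay, with a stated time of 48 h; on this read-out lower numbers stand for stronger inhibition and higher numbers for weaker inhibition: compound 1 gives 59800 nM, the highest of the three numbers. Its two measured relatives differ from it only on the saturated chain carbon bound to the amide-type nitrogen. Compound 2 `COc1ccc(CN(C(=O)CSc2nc3ccccc3s2)c2cc(OC)c(OC)c(OC)c2)cc1N` gives 491 nM, and compound 3 `COc1ccc(CN(C(=O)CSc2nc3ccccc3s2)c2cc(OC)c(OC)c(OC)c2)cc1N=[N+]=[N-]` gives 2860 nM. Both changes were large: a 120-fold lower number from compound 1 to compound 2 (2.09 log units; beyond the scatter), and a 21-fold lower number from compound 1 to compound 3 (1.32 log units; beyond the scatter); between the two, a 5.8-fold higher number from compound 2 to compound 3 (0.77 log units; beyond the scatter). Compound 4 `COc1ccc(CN(C(=O)CSc2nc3ccccc3s2)c2cc(OC)c(OC)c(OC)c2)cc1OC` takes the same route with a third variant of the group: 3,4-dimethoxyphenyl in place of 4-fluorophenyl on a saturated chain carbon bound to an amide-type nitrogen. Both measured steps from compound 1 bear on this change, as each likewise removed the 4-fluorophenyl, and each lowered the number by a large amount. Within the data shown here, a large drop is therefore expected here too, with a size placed between the two measured ones, though no measured compound shows this exact group. Compound 4 is estimated at 3000 nM, with a likely range from 500 nM to 15000 nM. That estimate corresponds to an expected 20-fold lower number from compound 1 to compound 4 (1.30 log units; beyond the scatter).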

Compound 4, half-maximal inhibitory concentration: 33900 nM
The estimate for compound 4 lay 11-fold (1.05 log units) below the measured number; measured number above the stated range.
By their numbers in this assay, from the lowest: compound 2; then compound 3; then compounds 4 and 1 (each within the scatter of the next).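

In this assay, among these compounds, the exchange of 4-fluorophenyl for 3,4-dimethoxyphenyl on this saturated chain carbon gives a 1.8-fold lower number from compound 1 to compound 4 (0.25 log units; within the scatter) so removing the 4-fluorophenyl does not by itself bring the gain seen with the earlier compounds. What matters among the three 4-methoxy-bearing benzyl groups is the other group on the aromatic carbon: methoxy in place of azido gives a 12-fold higher number from compound 3 to compound 4 (1.07 log units; beyond the scatter) and methoxy in place of amino gives a 69-fold higher number from compound 2 to compound 4 (1.84 log units; beyond the scatter) so a second methoxy does not reproduce the effect of either nitrogen group. No measurement here explains these differences.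

The compounds shown leave open whether the amino result is specific to that group or would carry over to a hydroxy, methylamino or acetamido group on the same aromatic carbon. They also leave open whether the amino group would keep its effect without the neighbouring methoxy group.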